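A fluoro swap on an ethylsulfanyl compound

The source may hold more compounds than are shown below. What is called first, only, known or untested is meant among the compounds shown, and "the series" means these compounds.

Measured in a functional assay on the whole organism for antagonist activity, with Mus musculus as the target; on this read-out higher numbers stand for an effect only at larger amounts of compound and lower numbers for an effect already at smaller amounts:
compound 1 `Cn1c(-c2ccccc2)nnc1S(C)(=O)=O`: 12.8 mg/kg
compound 2 `CCSc1nnc(-c2ccccc2)n1C`: > 200 mg/kg (a limit of the assay, not a number)
compound 3 `CC[S+]([O-])c1nnc(-c2ccccc2)n1C`: 14.4 mg/kg

Compound 2 gives only a limit: > 200 mg/kg. It is the least potent of the three, as an at least 15-fold higher number from compound 1 to compound 2 (1.19 log units; beyond the scatter) and an at least 13-fold lower number from compound 2 to compound 3 (1.14 log units; beyond the scatter) show. Both steps are large, while a 1.1-fold higher number from compound 1 to compound 3 (0.05 log units; within the scatter) stays within the scatter.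

Compound 4 `CCSc1nnc(-c2ccccc2F)n1C` keeps the ethylsulfanyl group of compound 2. The change is fluoro in place of hydrogen on an aromatic carbon, which puts fluoro in place of hydrogen on an aromatic carbon of a six-membered aromatic ring of carbon only.

Going by the values given here, no measured step touches that ring. All three change the group on the sulfur side, so they show only that this assay can respond strongly to a single change, as in an at least 13-fold lower number from compound 2 to compound 3 (1.14 log units; beyond the scatter). Compound 2 has no exact number to start from, so any measurable result would appear as a lower number, and another limit is quite possible.

The expected change is an at least 1.6-fold lower number from compound 2 to compound 4 (0.22 log units; that floor lies within the scatter). For compound 4 the estimated value is 120 mg/kg, with an expected range of 30 mg/kg to 250 mg/kg.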

Compound 4, dose for half-maximal effect: 18.6 mg/kg
Compound 4: middle estimate off by 6.5-fold (0.81 log units), on the high side; measured number below the stated range.
By their numbers in this assay, from the lowest: compounds 1, 3 and 4 (each within the scatter of the next). At a limit, above all of these: compound 2.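

In this assay, fluoro in place of hydrogen on an aromatic carbon gives an at least 10-fold lower number from compound 2 to compound 4 (1.03 log units; beyond the scatter). Earlier steps had shown large changes only on the sulfur side, whereas this one shows that a single change on the six-membered aromatic ring of carbon only can also matter strongly, with the ethylsulfanyl group kept. The true size of the step remains unknown, as its starting point is only a limit for compound 2: the limit of > 200 mg/kg in this assay, at which 1 of the 4 values shown sits.

The compounds shown leave open whether this gain is specific to fluoro or would also appear with chloro, methyl or an amine at the same place. They also leave open whether fluoro at this place would change the number when the ethylsulfanyl group is replaced by the methylsulfonyl group of compound 1.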